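Propoxy to 4-Chlorobenzyloxy: Expected Cytotoxicity of Compound 4

A few compounds are considered here, and "the series" means these few. Any claim that something is new, unique, unknown or untested is made for them only; others in the source may bear on it.

compound 1 `CCCOc1c(OC)c(OC)cc2c1C(=O)[C@]1(OC)C=C[C@H]2N(C(=O)OCC)N1C(=O)OCC`: > 300 ug/mL
compound 2 `COC(=O)N1[C@@H]2C=C[C@@](OC)(C(=O)c3c2cc(OC)c(OC)c3OCc2ccc(F)cc2)N1C(=O)OC`: 56.6 ug/mL
compound 3 `COC(=O)N1[C@@H]2C=C[C@@](OC)(C(=O)c3c2cc(OC)c(OC)c3OCc2ccc(OC)cc2)N1C(=O)OC`: > 300 ug/mL

In an ADME assay on KB cells (Homo sapiens) for cytotoxicity (a lower number here means that less compound is needed, a higher number that more compound is needed for the effect), compound 1 gives only a limit, > 300 ug/mL. Compound 2 gives 56.6 ug/mL. Compound 3 likewise gives only a limit, > 300 ug/mL. Compound 4 `CCOC(=O)N1[C@@H]2C=C[C@@](OC)(C(=O)c3c2cc(OC)c(OC)c3OCc2ccc(Cl)cc2)N1C(=O)OCC` is not yet measured; it differs from compound 1 by 4-chlorophenyl in place of ethyl on a saturated chain carbon bound to an oxygen on an aromatic ring. Within the data shown here, no measured step carries this exact change. The nearest evidence is the step of an at least 5.3-fold higher number from compound 2 to compound 3 (0.72 log units; beyond the scatter), which sets fluoro against methoxy on an aromatic carbon, with two of the three values sitting at the limit of > 300 ug/mL in this assay, at which 2 of the 3 values shown sit. Chloro on that aromatic carbon is expected to place compound 4 nearer compound 2 than compound 3, so the step of an at least 3.7-fold lower number from compound 1 to compound 4 (0.57 log units; beyond the scatter) is expected toward a lower number. Compound 4 is estimated at 80 ug/mL, within 30 ug/mL to 300 ug/mL.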

Compound 4, concentration for half-maximal effect: 99.9 ug/mL
The estimate for compound 4 lay 1.2-fold (0.10 log units) below the measured number; the range from low to high includes it.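

On the saturated chain carbon bound to an oxygen on an aromatic ring, 4-chlorophenyl in place of ethyl gives an at least 3.0-fold lower number from compound 1 to compound 4 (0.47 log units; beyond the scatter) in this assay. The earlier step changed only a group on an aromatic carbon, whereas this one replaces the ethyl end of the chain with a ring. From the compounds shown here alone, compound 1 gives > 300 ug/mL, which is a limit, so the true size of the step remains unknown.

Going by these compounds, what a plain benzyl or a longer chain such as pentyl would give here remains open. The compounds shown therefore do not separate the contribution of the ring from that of the chloro.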